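Methoxy in Place of Methyl: Compound 1 to Compound 3

This account rests on a few compounds, and the source may have more. Where it says the series, first, only, none or still open, it means among the compounds named here.

Measured compounds:
compound 1, `COc1cc(-n2ncnc2-c2ccc(C)cc2)cc(OC)c1OC`: 540 nM
compound 2, `COc1cc(-c2ncnn2-c2cccc(N)c2)cc(OC)c1OC`: > 10000 nM

Among the compounds with values here, compound 1 `COc1cc(-n2ncnc2-c2ccc(C)cc2)cc(OC)c1OC` is the one compound with a numerical result in a functional assay on MCF7 cells (Homo sapiens) for antiproliferative activity, read by MTT assay, with a stated time of 72 h; on this read-out lower numbers stand for stronger inhibition and higher numbers for weaker inhibition; in that assay compound 1 gives 540 nM. Compound 2 `COc1cc(-c2ncnn2-c2cccc(N)c2)cc(OC)c1OC` returns in this assay only > 10000 nM, which is a limit of the assay and not a number. Compound 1 thus stands as the only number shown, with the limit of > 10000 nM in this assay, at which 1 of the 2 values shown sits, as the sole other value. Within the data shown here, since the two measured compounds differ in more than one place, no single step between them is available, and nothing measured describes the change that leads to compound 3.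

Compound 3 `COc1ccc(-c2ncnn2-c2cc(OC)c(OC)c(OC)c2)cc1` differs from compound 1 in one place: methoxy in place of methyl on an aromatic carbon. The step of a 1.4-fold lower number from compound 1 to compound 3 (0.13 log units; within the scatter) is expected to be small, at most a modest shift toward stronger inhibition and possibly none beyond the usual scatter. For compound 3 in this assay a value of 400 nM is estimated, with a plausible range from 120 nM to 1500 nM.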

Compound 3, half-maximal inhibitory concentration: 360 nM
Compound 3: middle estimate off by 1.1-fold (0.05 log units), on the high side; low and high end bracket the measured number.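

In this assay, methoxy in place of methyl on an aromatic carbon, para to a large group, gives a 1.5-fold lower number from compound 1 to compound 3 (0.18 log units; within the scatter), so the 4-methylphenyl and 4-methoxyphenyl compounds cannot be told apart on this read-out. Within the data shown here, until this result, compound 1 was the only compound with a number, and this pair now shows that this position can take a second group, one with an added oxygen and a hydrogen-bond acceptor, while the result stays within the usual scatter. Nothing measured here explains why the swap leaves the number in the same range, and no measured property bears on this step.

The compounds shown leave open whether an amine, a hydroxyl or a longer chain such as ethoxy at this same place would also keep the value in this range, since both groups compared so far are small. Compound 2 stands at > 10000 nM, a limit of the assay and not a number, and as it differs from compound 1 in more than one place, it cannot show which of its differences matters.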